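This account rests on a few compounds, and the source may have more. Where it says the series, first, only, none or still open, it means among the compounds named here.

Compound 1, `Cc1cccc(C2(CNC(=O)Nc3c(C(C)C)cccc3C(C)C)CCCC2)c1`, gives 15 nM in an assay on microsomes for inhibition of acyl-CoA:cholesterol acyltransferase (Oryctolagus cuniculus); on this read-out lower numbers stand for stronger inhibition and higher numbers for weaker inhibition.
Compound 2, `COc1ccc(C2(CNC(=O)Nc3c(C(C)C)cccc3C(C)C)CCCC2)cc1`, gives 31 nM in this assay.
Compound 3, `CC(C)c1cccc(C(C)C)c1NC(=O)NCC1(c2cccc([N+](=O)[O-])c2)CCCC1`, gives 51 nM in this assay.

Of these three numbers, compound 3 has the highest. Its nearest neighbour is compound 2, the step being a 1.6-fold higher number from compound 2 to compound 3 (0.22 log units; within the scatter); the furthest is compound 1, the step being a 3.4-fold higher number from compound 1 to compound 3 (0.53 log units; beyond the scatter). Compound 4, `CC(C)c1cccc(C(C)C)c1NC(=O)NCC1(c2cccc(N)c2)CCCC1`, has not yet been measured in this assay. It differs from compound 3 in one place: amino in place of nitro on an aromatic carbon.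

Among the measured compounds shown here, none of the measured steps exchanges nitro for amino. For the measured compounds named here, the only step that touches this position is a 3.4-fold higher number from compound 1 to compound 3 (0.53 log units; beyond the scatter), in which nitro replaced methyl; the step of a 1.6-fold higher number from compound 2 to compound 3 (0.22 log units; within the scatter) exchanged the whole aryl group and stayed within the scatter. Within these three compounds, changes on this ring moved the number by a modest amount at most, and the measured data give no direction for an amino group in particular. The expected step is therefore small, a 1.2-fold higher number from compound 3 to compound 4 (0.07 log units; within the scatter). For compound 4 the estimated value in this assay is 60 nM, with a range from 25 nM to 150 nM.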

Compound 4, half-maximal inhibitory concentration: 21 nM
The estimate for compound 4 lay 2.9-fold (0.46 log units) above the measured number; the whole stated range lies above it.
By their numbers in this assay, from the lowest: compounds 1, 4, 2 and 3 (each within the scatter of the next, the first and the last beyond it).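

Among the compounds shown here, the exchange of nitro for amino gives the first direct reading of this aromatic carbon with the rest of the compound unchanged, and in this assay it produces a step beyond the scatter (a 2.4-fold lower number from compound 3 to compound 4 (0.39 log units; beyond the scatter)), so the choice between these two groups does register on this read-out. The amino compound also cannot be told apart from the other two: the step with amino in place of methyl (a 1.4-fold higher number from compound 1 to compound 4 (0.15 log units; within the scatter)) lies within the scatter, as does the step with 3-aminophenyl in place of 4-methoxyphenyl (a 1.5-fold lower number from compound 2 to compound 4 (0.17 log units; within the scatter)), and at this carbon nitro alone stands apart, from both methyl and amino. No measurement is at hand that would account for the step from nitro to amino.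

The compounds shown leave open whether a hydroxyl, an acetamide or a dimethylamino group on the same carbon would read like amino and methyl or like nitro. They also leave open whether the exchange of nitro for amino would give a step of similar size on another carbon of this ring.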